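The compounds below may be only part of what the source reports. "The series", "measured", "known", "first", "only" and "open" are said of these compounds alone.

Compound 2 `COc1ccc(Nc2nnnn2-c2cccc(Cl)c2)cc1` is measured in an ADME assay on HaCaT cells (Homo sapiens) for cytotoxicity, read by MTT assay, with a stated time of 72 h (a higher number here means a weaker inhibitor, a lower number a stronger inhibitor), at 103000 nM. Compound 1 `COc1ccc(Nc2nnnn2-c2ccc(Br)cc2)cc1` gives 103000 nM in this assay, level with compound 2, and compound 3 `COc1ccc(-n2nnnc2Nc2ccccc2Br)cc1` gives 137000 nM, which lies within the scatter of both. Compound 4 `COc1ccc(Nc2nnnn2-c2ccc(Cl)cc2)cc1` has not been measured; the difference from compound 2 is 4-chlorophenyl in place of 3-chlorophenyl on an aromatic nitrogen. Going by the values given here, one measured step bears on this change: the move from a 4-bromophenyl to a 3-chlorophenyl on the aromatic nitrogen gave no change at the digits printed from compound 1 to compound 2 (within the scatter). Since moving the halogen around that ring left the number unchanged there, the step expected for compound 4 is no change at the digits printed from compound 2 to compound 4 (within the scatter), that is, nothing beyond the scatter. Compound 4 is therefore estimated at 103000 nM, within a range from 60000 nM to 180000 nM.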

Compound 4, half-maximal inhibitory concentration: 102000 nM
Beside the measured number, compound 4's estimate is 1.0-fold (0.00 log units) above it; the range from low to high includes it.
By their numbers in this assay, from the lowest: compounds 4, 1, 2 and 3 (each within the scatter of the next).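

In this assay, 4-chlorophenyl in place of 3-chlorophenyl gives a 1.0-fold lower number from compound 2 to compound 4 (0.00 log units; within the scatter) and so isolates the place of the chlorine, which the earlier step changed together with the halogen. Chloro in place of bromo, with the place held, gives a 1.0-fold lower number from compound 1 to compound 4 (0.00 log units; within the scatter) and shows that the halogen alone makes no difference beyond the scatter on this ring. No measurement shown explains why these numbers stay level. Still open, on these data alone, is whether an amine, a carboxylic acid or a longer chain on this ring would shift the number.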